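A Benzylidene Hydrazone Extension on a Thiourea Side Chain

The source may hold more compounds than are shown below. What is called first, only, known or untested is meant among the compounds shown, and "the series" means these compounds.

Compound 1 `CC1=CC[C@@H]([C@@](C)(O)CCCC(C)(C)NC=S)CC1` and compound 2 `CC1=CC[C@@H]([C@@](C)(O)CCCC(C)(C)NC(=S)NN)CC1` share a core and differ only at the thiocarbonyl carbon. In a functional assay on PCO3 cells (Homo sapiens) for cytotoxicity, read by sulforhodamine B assay (a lower number here means a stronger inhibitor of growth, a higher number a weaker inhibitor of growth), compound 1 gives 72000 nM. Compound 2 reaches only the limit of this assay, > 100000 nM, so no number is known for it. The change an at least 1.3-fold higher number from compound 1 to compound 2 (0.14 log units; that floor lies within the scatter) is thus open-ended, and compound 2 stands at the limit of > 100000 nM in this assay, at which 1 of the 2 values shown sits. Compound 3 `CC1=CC[C@@H]([C@@](C)(O)CCCC(C)(C)NC(=S)N/N=C\c2ccccc2)CC1` is the next step: a group of 8 heavy atoms (7 carbon, 1 nitrogen; one six-membered aromatic ring of carbon only) in place of one nitrogen atom, on an amide-type nitrogen. Going by the values given here, the one measured step, from compound 1 to compound 2, alters the substituent on the thiocarbonyl carbon and does not touch the amide-type nitrogen that now changes, so it offers no direct guide to this assay for compound 3. Among the compounds with values here, both measured compounds are weak inhibitors of growth in this assay, and the hydrazone side chain built onto compound 2 has no measured precedent here. The expectation for compound 3 is a value near that of compound 2, with wide bounds, and the step of an at least 1.2-fold lower number from compound 2 to compound 3 (0.09 log units; that floor lies within the scatter) is an estimate only. Compound 3 is expected to give 80000 nM, between 20000 nM and 200000 nM.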

Compound 3, concentration for total growth inhibition: 36200 nM
Compound 3: middle estimate off by 2.2-fold (0.34 log units), on the high side; low and high end bracket the measured number.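

Placing the group with its six-membered aromatic ring on the amide-type nitrogen gives an at least 2.7-fold lower number from compound 2 to compound 3 (0.44 log units; beyond the scatter), the first step among these compounds in this assay that clears the usual scatter. As far as these compounds go, the true size of that step remains unknown, as compound 2 has only a limit and no number: the limit of > 100000 nM in this assay, at which 1 of the 3 values shown sits. Compared with compound 1, which differs from compound 3 only at the thiocarbonyl carbon, the change gives a 2.0-fold lower number from compound 1 to compound 3 (0.30 log units; within the scatter), so the two cannot be told apart, and this position accepts the much larger group while growth inhibition stays in the same weak range.

The compounds shown do not reveal whether the step from the amino compound depends on the aromatic ring itself, on the double bond that links it to the nitrogen, or on both. A saturated benzyl group on the same nitrogen could separate the role of the double bond, while a pyridine ring, or a chlorine atom on the aromatic ring, could test whether this ring can be changed without losing what was gained.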